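A few compounds are considered here, and "the series" means these few. Any claim that something is new, unique, unknown or untested is made for them only; others in the source may bear on it.

Measured so far in a functional assay on MCF7 cells (Homo sapiens) for cytotoxicity, read by MTT assay, with a stated time of 48 h; a lower number here means a stronger inhibitor, a higher number a weaker inhibitor:
- compound 1 `O=C1CS/C(=N/c2ccccc2)N1Cc1ccncc1` — 65800 nM
- compound 2 `COc1ccc(/C=C2/S/C(=N/c3ccccc3)N(Cc3ccncc3)C2=O)cc1` — 31500 nM
- compound 3 `O=C1/C(=C\c2ccc(O)c(O)c2)S/C(=N/c2ccccc2)N1Cc1ccncc1` — 12400 nM

Compound 3 gives the lowest number of the three. For the measured compounds named here, its nearest neighbour is compound 2, and the only single-point step so far runs between those two: a 2.5-fold lower number from compound 2 to compound 3 (0.40 log units; beyond the scatter). Going by the values given here, compound 1, which carries no group at all on the double-bonded chain carbon, stands furthest from compound 3; the two values show compound 1 to be the weaker of that pair, but no single-point step connects them.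

Compound 4 `Cc1ccc(/C=C2/S/C(=N/c3ccccc3)N(Cc3ccncc3)C2=O)s1` is not yet measured in this assay. Relative to compound 3 the change is 5-methylthiophen-2-yl in place of 3,4-dihydroxyphenyl on a double-bonded chain carbon bound to a double-bonded ring carbon. Among the compounds with values here, no measured step covers this exact exchange. The step from compound 2 to compound 3 is the one that bears on it, since it also swaps the group on the double-bonded chain carbon, and it was modest. The 5-methylthiophen-2-yl group resembles the 4-methoxyphenyl group of compound 2 more than the 3,4-dihydroxyphenyl group of compound 3 in lacking hydrogen-bond donors, so the number for compound 4 is expected to move back toward compound 2, giving a step of a 2.3-fold higher number from compound 3 to compound 4 (0.35 log units; beyond the scatter). The estimate for compound 4 is therefore 28000 nM, with a range from 12000 nM to 65000 nM.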

Compound 4, half-maximal inhibitory concentration: 28700 nM
Compound 4: the middle estimate sits 1.0-fold (0.01 log units) below what was measured, and the stated range covers the measured number.
By their numbers in this assay, from the lowest: compound 3; then compounds 4 and 2 (each within the scatter of the next); then compound 1.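

In this assay, for the compounds shown here, 5-methylthiophen-2-yl is the first five-membered aromatic ring with a hetero atom on the double-bonded chain carbon bound to a double-bonded ring carbon, and its exchange for 3,4-dihydroxyphenyl gives a modest step (a 2.3-fold higher number from compound 3 to compound 4 (0.36 log units; beyond the scatter)). Against 4-methoxyphenyl, the same ring gives a step that does not leave the scatter (a 1.1-fold lower number from compound 2 to compound 4 (0.04 log units; within the scatter)), so these two groups cannot be told apart here. Among the three compounds that carry an aromatic group at this place, compound 3, whose group has 2 hydrogen-bond donors, now stands apart from both others, but one such compound cannot separate the donors from the rest of the 3,4-dihydroxyphenyl group.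

The compounds shown leave open whether a single hydroxyl group would give the number of compound 3, and how an amine or a carboxylic acid on the aromatic ring would read. No measurement available here explains either step.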